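The source may report more compounds than this note shows. Statements on the series, on what has been measured and on what is new or still open speak of the compounds shown alone.

Measured compounds:
- compound 2: `CC#CC(CC(=O)O)c1ccc(OCC2COc3ccc(Cl)cc3O2)cc1` — in a functional assay on HEK293 cells for agonist activity at Free fatty acid receptor 1 (Homo sapiens), read by fluorescence and calcium flux, with a stated time of 10 min (a higher number here means that more compound is needed for the effect, a lower number that less compound is needed), compound 2 gives 100 nM
- compound 1: `O=C(O)CCc1ccc(OCC2COc3ccc(Cl)cc3O2)cc1F` — in this assay compound 1 gives 830 nM

Of these two numbers, compound 2 holds the lowest; compound 1 sits well beyond the scatter of repeated measurements from it, so compound 2 needs the smaller amount of material for the effect.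

Compound 3 is `CCOC(CC(=O)O)c1ccc(OCC2COc3ccc(Cl)cc3O2)cc1`. It differs from compound 2 in one place: ethoxy in place of prop-1-yn-1-yl on a saturated chain carbon bound to an aromatic carbon and a saturated chain carbon. The shared core, with its acid-bearing chain, is kept intact; only the group on the chain carbon bound to the aromatic ring changes. Going by the values given here, no pair of measured compounds shows this particular swap, so no step for it can be read off directly.

The expectation is for a modest rise, small but possibly beyond the scatter: the step from compound 2 to compound 3 is estimated at a 2.5-fold higher number from compound 2 to compound 3 (0.40 log units; beyond the scatter). Compound 3 is therefore expected to give about 250 nM in this assay, within a range of 80 nM to 800 nM.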

Compound 3, half-maximal effective concentration: 640 nM
The estimate for compound 3 lay 2.6-fold (0.41 log units) below the measured number; the measured number falls inside the stated range.
By their numbers in this assay, from the lowest: compound 2; then compounds 3 and 1 (each within the scatter of the next).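

On the saturated chain carbon bound to an aromatic carbon and a saturated chain carbon, the group clearly matters: in this assay, putting ethoxy in place of prop-1-yn-1-yl gives a 6.4-fold higher number from compound 2 to compound 3 (0.81 log units; beyond the scatter). Both groups have 3 heavy atoms and no ring, so this step shows that the number can move well beyond the scatter even when the heavy-atom count stays the same, with the triple bond leaving and an oxygen, a hydrogen-bond acceptor, entering. Nothing shown here gives a measured reason for this rise.

The compounds shown leave open whether losing the triple bond or gaining the oxygen matters more. A propyl group on the same carbon, which has neither feature, would help separate the two.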